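Swapping cyclopentyl for a carboxythiophene on compound 3

The source may report more compounds than this note shows. Statements on the series, on what has been measured and on what is new or still open speak of the compounds shown alone.

Values in a physicochemical assay for solubility, in phosphate buffer, with a stated time of 18 h; a lower number here means a less soluble compound, a higher number a more soluble compound:
Compound 1 `N#Cc1c(N)nc2nc(C3CCCC3)ncc2c1N`: 89000 nM
Compound 2 `N#Cc1c(N)nc2nc(Cc3ccccc3)ncc2c1N`: 13000 nM
Compound 3 `CC(C)(C)c1nc(C2CCCC2)c2c(N)c(C#N)c(N)nc2n1`: < 1000 nM (a limit)

Compound 3 sits at < 1000 nM, which is a limit of this assay and not a number. Compound 4 `CC(C)(C)c1nc(-c2ccc(C(=O)O)s2)c2c(N)c(C#N)c(N)nc2n1` differs from compound 3 in one place: 5-carboxythiophen-2-yl in place of cyclopentyl on an aromatic carbon. Cyclopentyl is thus replaced by 5-carboxythiophen-2-yl.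

Among the compounds with values here, only one measured step also removes cyclopentyl: a 6.8-fold lower number from compound 1 to compound 2 (0.84 log units; beyond the scatter). It points downward, but it is a modest step and brings in benzyl, not the group entering here. It is therefore a weak guide. The entering group carries a hydrogen-bond donor and acceptors, which cyclopentyl lacks, so an upward move is expected instead. The starting point is only a limit, so any size is rough. The expected change is an at least 20-fold higher number from compound 3 to compound 4 (1.30 log units; beyond the scatter). The estimate for compound 4 is 20000 nM, with an expected range from 2000 nM to 150000 nM.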

Compound 4, solubility: > 1000000 nM
Compound 4 ended at the assay's limit; the forecaster's own chance of this, stated with the estimate: 25%; at least 50-fold (1.69 log units) between middle value and limit.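

In this assay, within the data shown here, 5-carboxythiophen-2-yl in place of cyclopentyl on an aromatic carbon gives an at least 1000-fold higher number from compound 3 to compound 4 (3.00 log units; beyond the scatter), opposite in direction to the only earlier step that removes cyclopentyl, a 6.8-fold lower number from compound 1 to compound 2 (0.84 log units; beyond the scatter), which brought in benzyl on a different pair of compounds. Compound 3 stands at < 1000 nM, which is a limit and not a number: the limit of < 1000 nM in this assay, at which 1 of the 4 values shown sits. Compound 4 stands at > 1000000 nM, also a limit and not a number: the limit of > 1000000 nM in this assay, at which 1 of the 4 values shown sits.

As far as these compounds go, the full size of the step therefore remains unknown, with only its direction and minimum printed. From the compounds shown here alone, it also remains open whether the carboxylic acid or the thiophene ring drives the rise, and whether a plain thiophen-2-yl, a primary amide or an amine at this position would move the number as far.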